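The source may report more compounds than this note shows. Statements on the series, on what has been measured and on what is new or still open speak of the compounds shown alone.

Compound 2 `CSc1ccc(CN(Cc2ccc(C(C)(C)C)cc2)Cc2cc3cc(C)ccc3[nH]c2=O)cc1` shares its core with compound 1 `Cc1ccc2[nH]c(=O)c(CN(CCCO)Cc3ccc(C(C)(C)C)cc3)cc2c1`. In a toxicity assay on MDCK cells (Canis lupus familiaris) for cytotoxicity, read by crystal violet staining, with a stated time of 48 h (a higher number here means that more compound is tolerated, a lower number that less compound is tolerated), compound 1 gives only a limit, > 10000 nM. In this assay compound 2 also gives only a limit, > 5000 nM. The step that the two limits leave unreadable from compound 1 to compound 2 therefore cannot be read, as the limit of > 10000 nM in this assay, at which 1 of the 2 values shown sits, and the limit of > 5000 nM in this assay, at which 1 of the 2 values shown sits, show. Compound 3 `Cc1ccc2[nH]c(=O)c(CN(Cc3ccc(C(C)(C)C)cc3)C(C)c3ccc(N(C)C)c(Cl)c3)cc2c1` carries 1-(3-chloro-4-(dimethylamino)phenyl)ethyl in place of 4-(methylsulfanyl)benzyl on an amine nitrogen. Going by the values given here, no measured step bears on this change, and the two values shown give no direction. For compound 3 a step that the limit leaves unreadable from compound 2 to compound 3 is expected in this assay. Compound 3 is thus estimated at 8000 nM, with a range from 3000 nM to 25000 nM.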

Compound 3, half-maximal cytotoxic concentration: 9800 nM
Estimate against measurement, compound 3: 1.2-fold (0.09 log units) below, and the stated range covers the measured number.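

Going by these compounds alone, compound 3 is the only one of the three compounds that gives a number rather than a limit in this assay, so this group on the amine nitrogen puts a readable value on this position. Replacing the 3-hydroxypropyl group gives an at least 1.0-fold lower number from compound 1 to compound 3 (0.00 log units; that floor lies within the scatter), so no real drop in tolerated concentration can be claimed. The step from the 4-(methylsulfanyl)benzyl group cannot be read, because compound 2 gives only a limit: the limit of > 5000 nM in this assay, at which 1 of the 3 values shown sits.

The compounds shown leave open whether the chlorine or the dimethylamino group matters to this number. They also leave open how a carboxylic acid on this chain would read in this assay.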